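A few compounds are considered here, and "the series" means these few. Any claim that something is new, unique, unknown or untested is made for them only; others in the source may bear on it.

In a functional assay for inhibition, with Homo sapiens as the target; a lower number here means a stronger inhibitor, a higher number a weaker inhibitor:

Compound 1 `COC(=O)CCCCCCCCn1nc(-c2ccccc2)c(-c2ccccc2)c1-c1ccccc1`: 4300 nM
Compound 2 `O=C(O)CCCCCCCCCn1nc(-c2ccccc2)c(-c2ccccc2)c1-c1ccccc1`: 5500 nM
Compound 3 `CC(C)(C)OC(=O)COCCCCCCn1nc(-c2ccccc2)c(-c2ccccc2)c1-c1ccccc1`: > 62000 nM

Compound 3 stands at a limit of the assay, not at a number: > 62000 nM. Compound 4 `O=C(O)C[S+]([O-])CCCCCCn1nc(-c2ccccc2)c(-c2ccccc2)c1-c1ccccc1` differs from it in one place, on a saturated chain carbon, six bonds along the chain from an aromatic nitrogen: a group of 6 heavy atoms (2 carbon, 3 oxygen, 1 sulfur; no ring) in place of a group of 9 heavy atoms (6 carbon, 3 oxygen; no ring), on a saturated chain carbon, six bonds along the chain from an aromatic nitrogen. The group leaving is (tert-butoxycarbonyl)methoxy. Among the measured compounds shown here, three measured steps bear on this. The step of a 1.3-fold higher number from compound 1 to compound 2 (0.11 log units; within the scatter) shows compounds 1 and 2 within the scatter of each other, while an at least 14-fold higher number from compound 1 to compound 3 (1.15 log units; beyond the scatter) and an at least 11-fold higher number from compound 2 to compound 3 (1.05 log units; beyond the scatter) are both large. Compound 4 keeps no tert-butoxycarbonyl group, so it is expected to lie nearer compound 2 at 5500 nM. The expected step is an at least 5.1-fold lower number from compound 3 to compound 4 (0.71 log units; beyond the scatter), toward a lower number in this assay. For compound 4 the estimated value is 12000 nM, with an expected range of 3000 nM to 50000 nM.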

Compound 4, half-maximal inhibitory concentration: 6500 nM
Compound 4: the middle estimate sits 1.8-fold (0.27 log units) above what was measured; the range from low to high includes it.
By their numbers in this assay, from the lowest: compounds 1, 2 and 4 (each within the scatter of the next). At a limit, above all of these: compound 3.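

Compound 3 gives only a limit in this assay, not a number: the limit of > 62000 nM in this assay, at which 1 of the 4 values shown sits.

Replacing its (tert-butoxycarbonyl)methoxy at this saturated chain carbon with the sulfur-bearing group gives an at least 9.5-fold lower number from compound 3 to compound 4 (0.97 log units; beyond the scatter), so this position can return to a measurable value with sulfur in the chain. The new group also reads level with the earlier chain ends, with a 1.2-fold higher number from compound 2 to compound 4 (0.07 log units; within the scatter) and a 1.5-fold higher number from compound 1 to compound 4 (0.18 log units; within the scatter).

The compounds shown leave open whether the tert-butyl ester or the chain oxygen goes with the limit, and how an amine or a shorter chain would read at this place.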